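A few compounds are considered here, and "the series" means these few. Any claim that something is new, unique, unknown or untested is made for them only; others in the source may bear on it.

Measured so far in an assay on Sf9 cells for inhibition of protein deacetylase HDAC6 (Homo sapiens), read by fluorescence, with a stated time of 40 min; a higher number here means a weaker inhibitor, a lower number a stronger inhibitor:
compound 1, `O=C(NO)c1ccc(NCc2nc(-c3ccccc3)nn2-c2cccc(Cl)c2)cc1`, gives 678 nM;
compound 2, `O=C(NO)c1ccc(NCc2nc(-c3ccccc3)nn2-c2ccc(F)cc2)cc1`, gives 274 nM.

Of these two numbers, compound 2 has the lower one, and the gap to compound 1 lies beyond the scatter, so on what is shown compound 2 stands as the stronger inhibitor. Within the data shown here, the single measured step, the change of 3-chlorophenyl to 4-fluorophenyl on the aromatic nitrogen, gave a 2.5-fold lower number from compound 1 to compound 2 (0.39 log units; beyond the scatter). The next compound, compound 3, `O=C(NO)c1ccc(NCc2nc(-c3ccccc3)nn2-c2ccccc2Cl)cc1`, differs from compound 2 in one place: 2-chlorophenyl in place of 4-fluorophenyl on an aromatic nitrogen. This change brings the chlorine back onto the ring that sits on the aromatic nitrogen, though at a different position from that in compound 1, and removes the fluorine that compound 2 carries. Among the measured compounds shown here, the only measured step that bears on it is a 2.5-fold lower number from compound 1 to compound 2 (0.39 log units; beyond the scatter), and that step ran in the direction of a lower number when fluorine replaced chlorine. Reversing part of that exchange is therefore expected to move the number back upward, to a modest degree, with the new position of the chlorine left uncertain by the data. Compound 3 is expected to give about 520 nM in this assay, within a range from 200 nM to 1400 nM, which means an expected step of a 1.9-fold higher number from compound 2 to compound 3 (0.28 log units; within the scatter).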

Compound 3, half-maximal inhibitory concentration: 669 nM
The estimate for compound 3 lay 1.3-fold (0.11 log units) below the measured number; measured number inside the range.
By their numbers in this assay, from the lowest: compound 2; then compounds 3 and 1 (each within the scatter of the next).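

In this assay, among these compounds, the exchange of 4-fluorophenyl for 2-chlorophenyl on the aromatic nitrogen gave a 2.4-fold higher number from compound 2 to compound 3 (0.39 log units; beyond the scatter), which leaves 4-fluorophenyl as the only one of the three groups whose number lies beyond the scatter from both others. Moving the chlorine around the same ring, a comparison the earlier compounds could not offer, gave a 1.0-fold lower number from compound 1 to compound 3 (0.01 log units; within the scatter), so 2-chlorophenyl and 3-chlorophenyl cannot be told apart in this assay and, for these two groups, the place of the chlorine shows no effect. No supporting information is available on why the fluorinated ring gives a different number from the two chlorinated rings.

The halogen and its place on the ring change together in the step to the fluorinated ring, so the compounds shown cannot separate the effect of fluorine from that of its position. On these data alone, how an unsubstituted phenyl ring, or a phenyl ring carrying a methoxy group or an amine, would behave on this aromatic nitrogen also stays open.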